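This account rests on a few compounds, and the source may have more. Where it says the series, first, only, none or still open, it means among the compounds named here.

Measured compounds in a functional assay on A549 cells (Homo sapiens) for antiproliferative activity, read by MTT assay, with a stated time of 48 h, in the presence of a further agent that is not named here; a lower number here means a stronger inhibitor of growth, a higher number a weaker inhibitor of growth:
- compound 1 `O=C(NOCc1ccccc1)c1cn(-c2ccccc2)nc1-c1ccccc1`: 5000 nM
- compound 2 `O=C(NOCc1ccccc1Cl)c1cn(-c2ccccc2)nc1-c1ccccc1`: 10300 nM

Going by the values given here, compound 1 stands at the lowest of the two numbers in this assay; compound 2 is its only neighbour, and the step of a 2.1-fold higher number from compound 1 to compound 2 (0.31 log units; beyond the scatter) is a modest one, yet beyond the scatter.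

Compound 3 `O=C(NOCc1ccccc1)c1cn(-c2ccccc2)nc1-c1ccc(Cl)cc1` differs from compound 1 by chloro in place of hydrogen on an aromatic carbon, placed on an aromatic carbon of a six-membered aromatic ring of carbon only, para to a large group. The same difference, cut one bond further out, reads phenyl to 4-chlorophenyl.

Among the compounds with values here, the one step that bears on this is a 2.1-fold higher number from compound 1 to compound 2 (0.31 log units; beyond the scatter), where chloro in place of hydrogen on an aromatic carbon gave a modest rise. That chloro sits on a different ring, so its weight for compound 3 is limited. A small rise or no change beyond the scatter is expected in this assay; the step expected is a 1.3-fold higher number from compound 1 to compound 3 (0.11 log units; within the scatter). For compound 3 the estimate is 6500 nM, within 2500 nM to 16000 nM.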

Compound 3, concentration for 50% growth inhibition: 13000 nM
Estimate against measurement, compound 3: 2.0-fold (0.30 log units) below, within the range that was stated.
By their numbers in this assay, from the lowest: compound 1; then compounds 2 and 3 (each within the scatter of the next).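

In this assay, phenyl to 4-chlorophenyl on the core of compound 1 is not a neutral change: the result is a 2.6-fold higher number from compound 1 to compound 3 (0.41 log units; beyond the scatter) and it lies beyond the scatter as printed. With a 2.1-fold higher number from compound 1 to compound 2 (0.31 log units; beyond the scatter) alongside it, chloro in place of hydrogen has now been seen on two different rings, and in both cases the number rises, so neither chloro compound improves on compound 1. Nothing measured here bears on why the number rises at either place.

Going by these compounds, whether the rise belongs to chloro alone or also to other groups stays open, for example fluoro, methoxy or an amine in the same place. The remaining phenyl of the shared core carries no substituent in any compound shown, so its response is also unknown.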